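Swapping the isopropyl for a piperazinylmethyl on the chain

A few compounds are considered here, and "the series" means these few. Any claim that something is new, unique, unknown or untested is made for them only; others in the source may bear on it.

Three analogues sharing one core have been measured in a functional assay on PC-3 cells (Homo sapiens) for antiproliferative activity, read by MTT assay, with a stated time of 72 h; on this read-out higher numbers stand for weaker inhibition and lower numbers for stronger inhibition. Compound 1 `COc1cc2ncnc(N3CCc4ccccc43)c2cc1NC(=O)/C=C/C(C)C` gives 6530 nM, compound 2 `C=C(C)C(=O)Nc1cc2c(N3CCc4ccccc43)ncnc2cc1O[C@@H]1CCOC1` gives 4910 nM, and compound 3 `CC(C)/C=C/C(=O)Nc1cc2c(N3CCc4ccccc43)ncnc2cc1O[C@@H]1CCOC1` gives 11200 nM. Compound 3 thus stands with the highest number of the three, although its gap to compound 1 is within the scatter: the step of a 1.7-fold higher number from compound 1 to compound 3 (0.23 log units; within the scatter) and the step of a 2.3-fold higher number from compound 2 to compound 3 (0.36 log units; beyond the scatter) are the two comparisons available, and only the second lies beyond the scatter.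

Compound 4 `CN1CCN(C/C=C/C(=O)Nc2cc3c(N4CCc5ccccc54)ncnc3cc2O[C@@H]2CCOC2)CC1` differs from compound 3 by (4-methylpiperazin-1-yl)methyl in place of isopropyl on a double-bonded chain carbon bound to a double-bonded chain carbon. Among the compounds with values here, the only measured step that touches the same place is the modest one from compound 2 to compound 3, and it does not involve the group now entering; no measured pair speaks to the piperazinylmethyl itself. A moderate change in either direction, or none beyond the scatter, is therefore all that can be expected in this assay. Compound 4 is estimated to show 5000 nM, within a range from 1500 nM to 15000 nM, which corresponds to an expected step of a 2.2-fold lower number from compound 3 to compound 4 (0.35 log units; beyond the scatter).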

Compound 4, half-maximal inhibitory concentration: 4210 nM
Compound 4: middle estimate off by 1.2-fold (0.07 log units), on the high side, and the stated range covers the measured number.
By their numbers in this assay, from the lowest: compounds 4, 2, 1 and 3 (each within the scatter of the next, the first and the last beyond it).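

In this assay, within the data shown here, the step from isopropyl to (4-methylpiperazin-1-yl)methyl on a double-bonded chain carbon bound to a double-bonded chain carbon gives a 2.7-fold lower number from compound 3 to compound 4 (0.42 log units; beyond the scatter), the first measured change at this place that involves an amine and a ring, and it is modest. On the carbonyl carbon, 3-(4-methylpiperazin-1-yl)prop-1-en-1-yl and 1-methylethenyl cannot be told apart, with a 1.2-fold lower number from compound 2 to compound 4 (0.07 log units; within the scatter), so of the three groups compared there, only 3-methylbut-1-en-1-yl stands apart from 1-methylethenyl. No supporting data are available to explain either step.

The compounds shown leave open whether the step depends on the piperazine ring or would also appear with an open-chain dimethylamino group or a morpholine. On these data alone, it also remains open whether the same exchange gives a similar step when methyl replaces oxolan-3-yl on the oxygen, as in compound 1.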